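This account rests on a few compounds, and the source may have more. Where it says the series, first, only, none or still open, it means among the compounds named here.

In an ADME assay on MT4 cells (Homo sapiens) for cytotoxicity, read by MTT assay, with a stated time of 96 h (a higher number here means that more compound is tolerated, a lower number that less compound is tolerated), compound 2 `CN(C)CCCNc1ccc(/N=N/c2ccccc2)cc1` gives 17000 nM, and compound 1 `Cc1ccc(/N=N/c2ccc(NCCCN(C)C)cc2)cc1` gives 17000 nM, so the two stand level. Compound 3 `CN(C)CCCNc1ccc(/N=N/c2ccc([N+](=O)[O-])cc2)cc1` carries nitro in place of hydrogen on an aromatic carbon, para to a large group: nitro in place of hydrogen on an aromatic carbon. Among the measured compounds shown here, only one measured step bears on this change, no change at the digits printed from compound 1 to compound 2 (within the scatter). That step concerns methyl rather than nitro, so it is a thin guide. No shift beyond the scatter is therefore expected in this assay, and the expected step is a 1.3-fold lower number from compound 2 to compound 3 (0.12 log units; within the scatter). Compound 3 is estimated at 13000 nM, within an expected range of 5000 nM to 32000 nM.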

Compound 3, half-maximal cytotoxic concentration: 19000 nM
Beside the measured number, compound 3's estimate is 1.5-fold (0.16 log units) below it, and the stated range covers the measured number.
By their numbers in this assay, from the lowest: compounds 1, 2 and 3 (each within the scatter of the next).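

Among the compounds shown here, at this position, on an aromatic carbon para to a large group, the earlier compounds covered only methyl and hydrogen. Nitro widens that set, and this assay shows a 1.1-fold higher number from compound 2 to compound 3 (0.05 log units; within the scatter) and a 1.1-fold higher number from compound 1 to compound 3 (0.05 log units; within the scatter), so all three groups stand level within the scatter. No evidence is available to explain this result. Going by these compounds, whether an amine or a carboxylic acid at this position would also stand level remains open. So does whether a longer chain elsewhere on the shared core would move the number beyond the scatter.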